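Methyl in Place of Hydrogen on the Benzyl Ring

A few compounds are considered here, and "the series" means these few. Any claim that something is new, unique, unknown or untested is made for them only; others in the source may bear on it.

Compound 1 `COc1ccc2cc([C@H](C)c3nnc(SCc4ccc(F)cc4)n3-c3ccc(F)cc3)ccc2c1` gives in a functional assay on PC-3 cells (Homo sapiens) for cytotoxicity, read by MTT assay (a lower number here means a stronger inhibitor, a higher number a weaker inhibitor), only a limit, <= 400000 nM.
Compound 2 `COc1cccc(CSc2nnc([C@@H](C)c3ccc4cc(OC)ccc4c3)n2-c2ccc(F)cc2)c1` gives in this assay a value of 211000 nM.
Compound 3 `COc1ccc2cc([C@H](C)c3nnc(SCc4ccccc4)n3-c3ccc(Cl)cc3)ccc2c1` gives in this assay a value of 14200 nM.

Among the two numbers shown, compound 3 stands lowest; the nearest is compound 2, whose higher number lies beyond the scatter, and the third value is a limit. Going by the values given here, the one single-point step between measured compounds, a step that the limit leaves unreadable from compound 1 to compound 2, cannot be sized because of the limit of <= 400000 nM in this assay, at which 1 of the 3 values shown sits.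

Compound 4 `COc1ccc2cc([C@H](C)c3nnc(SCc4ccc(C)cc4)n3-c3ccc(Cl)cc3)ccc2c1` differs from compound 3 by methyl in place of hydrogen on an aromatic carbon. Among the compounds with values here, none of the measured steps touches a methyl on the benzyl ring, so nothing in the data bears directly on this change. Within the data shown here, with no comparable step to draw on, the expectation is that the step of a 1.0-fold lower number from compound 3 to compound 4 (0.01 log units; within the scatter) stays within the scatter, in no particular direction. Compound 4 is therefore estimated to give in this assay about 14000 nM, with a range from 5000 nM to 40000 nM.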

Compound 4, half-maximal inhibitory concentration: 8400 nM
For compound 4 the middle estimate is 1.7-fold (0.22 log units) above the measured one, and the stated range covers the measured number.
By their numbers in this assay, from the lowest: compounds 4 and 3 (each within the scatter of the next); then compound 2.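

On the benzyl ring, methyl in place of hydrogen gives in this assay a 1.7-fold lower number from compound 3 to compound 4 (0.23 log units; within the scatter). Going by these compounds alone, this is the first step at this position whose size can be read, and it shows that a methyl on this aromatic carbon, para to a large group, leaves the number within the scatter. No information given here explains this step.

What the compounds shown leave open is whether other groups on the same carbon, such as an amine, a carboxylic acid or a longer chain, would also stay within the scatter of compound 3. They also leave open whether methyl on the benzyl ring would give a similar step with 4-fluorophenyl in place of the 4-chlorophenyl that compound 3 and compound 4 carry.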